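The source may hold more compounds than are shown below. What is called first, only, known or untested is meant among the compounds shown, and "the series" means these compounds.

The measured compounds, tested in an assay on CHO cells for displacement of a labelled ligand from adenosine receptor A3 (Homo sapiens), read by scintillation counting, with a stated time of 120 min, tested at 10 uM; on this read-out lower numbers stand for less inhibition and higher numbers for more inhibition at the one concentration tested (going by the name of the read-out):
compound 1 `Nc1scc(CN2CCN(c3ccccc3C(F)(F)F)CC2)c1C(=O)c1ccc(Cl)cc1`: 0%
compound 2 `Nc1scc(CN2CCN(c3cccnc3)CC2)c1C(=O)c1ccc(Cl)cc1`: 0%
compound 3 `Nc1scc(CN2CCN(c3ccccc3F)CC2)c1C(=O)c1ccc(Cl)cc1`: 0%

Compound 3 stands level with compounds 1 and 2 in this assay; none of the three shows any inhibition at the single concentration tested. The change from compound 3 to compound 4 `Nc1scc(CN2CCN(c3c(F)cccc3F)CC2)c1C(=O)c1ccc(Cl)cc1` is fluoro in place of hydrogen on an aromatic carbon, which, taken one bond further out, reads as 2-fluorophenyl to 2,6-difluorophenyl. Among the measured compounds shown here, three measured steps bear on it, all of them exchanges at the same aryl group on the ring amine nitrogen: no change at the digits printed from compound 1 to compound 2 (within the scatter), no change at the digits printed from compound 1 to compound 3 (within the scatter) and no change at the digits printed from compound 2 to compound 3 (within the scatter). None of these moved the read-out beyond the scatter, not even the replacement of 2-(trifluoromethyl)phenyl by pyridin-3-yl. A step that adds a second fluoro to an aryl already carrying one has not been measured here. With every change at this aryl group so far leaving the read-out unmoved, the expected step is of no size beyond the scatter: no change at the digits printed from compound 3 to compound 4 (within the scatter). Compound 4 is therefore estimated at 0%, within a range of -10% to 10%.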

Compound 4, a percentage reported as inhibition, at one concentration (the size of the read-out at that concentration, not a potency): 4%
Compound 4: the middle estimate sits 4 percentage points below what was measured; measured number inside the range.
By their numbers in this assay, from the lowest: compounds 1, 2, 3 and 4 (each within the scatter of the next).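

In this assay a second fluoro on the aryl group, taking 2-fluorophenyl to 2,6-difluorophenyl, gives a number 4 percentage points higher from compound 3 to compound 4 (within the scatter) and so shows that adding a group at this place, not only exchanging one aryl group for another, stays within the scatter. Against the other aryl groups on the ring amine nitrogen, 2,6-difluorophenyl gives a number 4 percentage points higher from compound 2 to compound 4 (within the scatter) and a number 4 percentage points higher from compound 1 to compound 4 (within the scatter) and so joins them: all four aryl groups sit level at the one concentration tested. No evidence is at hand on why this read-out stays flat.

Still open, on these data alone, is whether anything on this nitrogen moves the read-out, such as a longer alkyl chain or a group carrying a carboxylic acid in place of the aryl ring. Also open, as far as these compounds go, is whether an amine in place of the chloro group would do so.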